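The source may hold more compounds than are shown below. What is called first, only, known or untested is meant among the compounds shown, and "the series" means these compounds.

Working notes on a toxicity assay on THP-1 cells (Homo sapiens) for inhibition; a higher number here means that more compound is tolerated, a lower number that less compound is tolerated. Compound 1 (`COc1ccc(-c2cnc(NC(=O)c3cccc(O)c3)n2C)cc1`) reads > 100000 nM, a limit of the assay. Compound 2 (`COc1ccc(-c2cnc(NC(=O)c3ccccc3C#N)n2C)cc1`) reads > 100000 nM, likewise a limit and not a number. Among the measured compounds shown here, the only measured step is a step that the two limits leave unreadable from compound 1 to compound 2, and the evidence so far is the limit of > 100000 nM in this assay, at which 2 of the 2 values shown sit. Compound 3 (`COc1ccc(-c2cnc(NC(=O)c3ccc(F)cc3)n2C)cc1`) differs from compound 2 in one place: 4-fluorophenyl in place of 2-cyanophenyl on a carbonyl carbon. Nothing measured gives a size or direction for this change, so no shift beyond the scatter is expected in this assay. The expected step is a number no higher from compound 2 to compound 3 (the limit leaves the size open). For compound 3 the estimate is 100000 nM, with an expected range of 40000 nM to 200000 nM.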

Compound 3, half-maximal cytotoxic concentration: >= 50000 nM
Compound 3: a limit, no number; the forecaster's own chance of this, stated with the estimate: 85%; the middle value lies beyond the limit too.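

No step can be read among compound 1, compound 2 and compound 3, since all three values are limits and not numbers. The compounds shown leave open whether any of these groups on the carbonyl carbon shifts the result in this assay, and by how much.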